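Methyl-to-fluoro step on the para-substituted aryl ring

This account rests on a few compounds, and the source may have more. Where it says the series, first, only, none or still open, it means among the compounds named here.

Measured compounds:
compound 1 `COc1cc2c(Oc3ccc(NC(=O)c4cc(-c5ccc(C)cc5)ccn4)cc3F)ccnc2cc1OCCCN1CCCC1`: 560 nM
compound 2 `COc1cc2c(Oc3ccc(NC(=O)c4cc(-c5ccc(F)cc5)ccn4)cc3F)ccnc2cc1OCCCN1CCCC1`: 1780 nM
compound 3 `COc1cc2c(Oc3ccc(NC(=O)c4nccc(-c5ccc(C)cc5)n4)cc3F)ccnc2cc1OCCCN1CCN(C)CC1`: "not determined" (no result reported)

In a functional assay on U-87MG ATCC cells (Homo sapiens) for cytotoxicity, read by MTT assay, with a stated time of 72 h (a lower number here means a stronger inhibitor, a higher number a weaker inhibitor), compound 1 gives 560 nM and compound 2 gives 1780 nM. The two differ only in fluoro in place of methyl on an aromatic carbon and the change gave a 3.2-fold higher number from compound 1 to compound 2 (0.50 log units; beyond the scatter). Compound 3 `COc1cc2c(Oc3ccc(NC(=O)c4nccc(-c5ccc(C)cc5)n4)cc3F)ccnc2cc1OCCCN1CCN(C)CC1` carries a different core; how the cores of compound 1 and compound 3 differ is not broken down here. In this assay compound 3 gives "not determined" (no result reported), so no result is reported for it. Compound 4 `COc1cc2c(Oc3ccc(NC(=O)c4nccc(-c5ccc(F)cc5)n4)cc3F)ccnc2cc1OCCCN1CCN(C)CC1` is not yet measured and differs from compound 3 in fluoro in place of methyl on an aromatic carbon; this is the same change as that from compound 1 to compound 2, at the same place. Since compound 3 has no value, the expectation for compound 4 can rest only on compound 1 and compound 2 and on the step of a 3.2-fold higher number from compound 1 to compound 2 (0.50 log units; beyond the scatter) seen between them. On that basis compound 4 is expected in this assay near 2000 nM, estimated to lie between 400 nM and 10000 nM.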

Compound 4, half-maximal inhibitory concentration: 910 nM
Beside the measured number, compound 4's estimate is 2.2-fold (0.34 log units) above it; the range from low to high includes it.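

In this assay compound 4 gives 910 nM, but compound 3 has no reported number, so no step can be read between compound 3 and compound 4. No evidence on hand bears on this result. The compounds shown leave open whether 4-methylphenyl to 4-fluorophenyl on the core of compound 3 repeats a 3.2-fold higher number from compound 1 to compound 2 (0.50 log units; beyond the scatter).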